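Sulfanyl substituent variation on a shared core: working notes

The source may hold more compounds than are shown below. What is called first, only, known or untested is meant among the compounds shown, and "the series" means these compounds.

Measured compounds:
compound 1 `Cc1cc(N2CC[C@@H](C)[C@@H](N(C)c3ncnc4[nH]ccc34)C2)n2nc(SCC3CCCCC3)nc2n1` — 11500 nM
compound 2 `Cc1cc(N2CC[C@@H](C)[C@@H](N(C)c3ncnc4[nH]ccc34)C2)n2nc(SCc3ccc(Cl)cc3)nc2n1` — 18400 nM
compound 3 `Cc1cc(N2CC[C@@H](C)[C@@H](N(C)c3ncnc4[nH]ccc34)C2)n2nc(SCCc3ccccc3)nc2n1` — 11800 nM

All three were read in a functional assay on HGC-27 cells (Homo sapiens) for inhibition, read by MTT assay, with a stated time of 72 h; on this read-out higher numbers stand for weaker inhibition and lower numbers for stronger inhibition. Compound 1 holds the lowest of the three numbers, but its nearest neighbour is compound 3 and its furthest is compound 2, and neither gap exceeds the scatter, so no order among the three can be claimed.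

The next compound, compound 4 `Cc1cc(N2CC[C@@H](C)[C@@H](N(C)c3ncnc4[nH]ccc34)C2)n2nc(SCc3csc4ccc(Cl)cc34)nc2n1`, differs from compound 1 in one place: 5-chloro-1-benzothiophen-3-yl in place of cyclohexyl on a saturated chain carbon bound to a sulfur.

For the measured compounds named here, two measured steps bear on this change, both starting from compound 1 and both altering the group on the saturated chain carbon bound to a sulfur. a 1.6-fold higher number from compound 1 to compound 2 (0.20 log units; within the scatter). a 1.0-fold higher number from compound 1 to compound 3 (0.01 log units; within the scatter). The third, a 1.6-fold lower number from compound 2 to compound 3 (0.19 log units; within the scatter), is also within the scatter. Swapping cyclohexyl for an aromatic group, with or without a chlorine, has so far moved the read-out by nothing beyond the scatter. A larger aromatic group carrying a chlorine is the new element, and nothing measured here speaks to it directly.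

The step to compound 4 is therefore expected to be a 1.1-fold higher number from compound 1 to compound 4 (0.04 log units; within the scatter), that is, none beyond the scatter. Compound 4 is estimated at 12500 nM, with a range from 5000 nM to 32000 nM.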

Compound 4, half-maximal inhibitory concentration: > 100000 nM
Compound 4 was reported as a limit; the forecaster's own chance of this, stated with the estimate: 5%; at least 8.0-fold (0.90 log units) between middle value and limit.
By their numbers in this assay, from the lowest: compounds 1, 3 and 2 (each within the scatter of the next). At a limit, above all of these: compound 4.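

Compound 4 stands in this assay only as a limit, not as a number: the limit of > 100000 nM in this assay, at which 1 of the 4 values shown sits.

The saturated chain carbon bound to a sulfur is therefore not indifferent to what it carries: 5-chloro-1-benzothiophen-3-yl gives an at least 8.6-fold higher number from compound 1 to compound 4 (0.93 log units; beyond the scatter) and an at least 8.4-fold higher number from compound 3 to compound 4 (0.92 log units; beyond the scatter) and an at least 5.4-fold higher number from compound 2 to compound 4 (0.73 log units; beyond the scatter) and all three steps lie beyond the scatter, whereas cyclohexyl, benzyl and 4-chlorophenyl stay within the scatter of one another. A chlorine alone does not separate these groups, since compound 2 also carries one and gives only a 1.6-fold higher number from compound 1 to compound 2 (0.20 log units; within the scatter) and what is new in compound 4 is the five-membered aromatic ring with a hetero atom, joined to a six-membered aromatic ring, in a group of 10 heavy atoms.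

Still open, going by these compounds, is whether the chlorine, the sulfur of the new ring or the size of the whole group sets this result, which 1-benzothiophen-3-yl without the chlorine or a naphthyl group on the same carbon would help to separate. Also open, on these data alone, is whether any group here can bring the read-out clearly under that of compound 1, for instance a chain ending in an amine or a carboxylic acid.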